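The source may report more compounds than this note shows. Statements on the series, on what has been measured and on what is new or still open speak of the compounds shown alone.

Among the compounds with values here, compound 2 `CCOC(=O)C1=C(C)NC(C)=C(C(=O)OCC)C1c1ccc(OCC(=O)NNC(=O)c2ccccc2)cc1` gives 44.9% in a functional assay on the whole organism (strain Wistar) for inhibition, with Rattus norvegicus as the target, read by paw edema, with stated times of 30 min and 3 h, at a dose of 20 mg/kg (on this read-out higher numbers stand for more inhibition at the one dose given (going by the name of the read-out) and lower numbers for less inhibition), the higher of the two numbers recorded so far; compound 1 `CCOC(=O)C1=C(C)NC(C)=C(C(=O)OCC)C1c1ccc(OCC(=O)NCc2ccccc2)cc1` gives 31.1% in this assay, and the only measured step, a number 13.8 percentage points higher from compound 1 to compound 2 (beyond the scatter), comes from benzamido in place of benzyl on an amide-type nitrogen. Compound 3 `CCOC(=O)C1=C(C)NC(C)=C(C(=O)OCC)C1c1ccc(OCc2nnc(S)o2)cc1` is not yet measured; it differs from compound 2 by 5-sulfanyl-1,3,4-oxadiazol-2-yl in place of benzamidocarbamoyl on a saturated chain carbon bound to an oxygen on an aromatic ring. Within the data shown here, no measured step concerns a change of this kind, so the one modest step offers no direct guide, and the expected step is a number 6.9 percentage points lower from compound 2 to compound 3 (within the scatter), not beyond the scatter. Compound 3 is therefore estimated at 38%, between 18% and 58%.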

Compound 3, a percentage reported as inhibition, in the whole organism at one dose (the size of the read-out at that dose, not a potency): 61.1%
Compound 3: middle estimate off by 23.1 percentage points, on the low side; the whole stated range lies below it.
By their numbers in this assay, from the lowest: compound 1; then compound 2; then compound 3.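

In this assay, 5-sulfanyl-1,3,4-oxadiazol-2-yl in place of benzamidocarbamoyl gives a number 16.2 percentage points higher from compound 2 to compound 3 (beyond the scatter), and in place of benzylcarbamoyl it gives a number 30 percentage points higher from compound 1 to compound 3 (beyond the scatter). On this saturated chain carbon bound to an oxygen on an aromatic ring, neither an amide-type nitrogen nor a six-membered aromatic ring of carbon only is needed, and compound 3 stands highest of the three. Nothing measured here accounts for the gain.

As far as these compounds go, it remains open whether the gain depends on the sulfanyl group or on the five-membered ring alone. An amine in place of the sulfanyl would separate the two, and a carboxylic acid on the same chain carbon would test whether any ring is needed.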